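Series notes: butoxycarbonyl to methylcarbamoyl, outlook for compound 4

The source may report more compounds than this note shows. Statements on the series, on what has been measured and on what is new or still open speak of the compounds shown alone.

Measured so far in an assay on COS-7 cells for inhibition of patatin-like phospholipase domain-containing protein 2 (Mus musculus), tested at 200 uM; on this read-out lower numbers stand for less inhibition and higher numbers for more inhibition at the one concentration tested (going by the name of the read-out):
compound 1 `CCOC(=O)c1cccc(-c2ccc(OCC)cc2)n1`: 79%
compound 2 `CCOc1ccc(-c2ccccc2)cc1`: 35%
compound 3 `CCCCOC(=O)c1cccc(-c2ccc(OCC)cc2)c1`: 61%

Compound 3 stands second highest of the three numbers. Compound 1 lies above it, beyond the scatter. Compound 2 lies below it, also beyond the scatter. Going by the values given here, the one step between neighbours, a number 26 percentage points higher from compound 2 to compound 3 (beyond the scatter), is butoxycarbonyl in place of hydrogen on an aromatic carbon.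

Compound 4 `CCOc1ccc(-c2cccc(C(=O)NC)c2)cc1` is the next compound. It differs from compound 3 by methylamino in place of butoxy on a carbonyl carbon; cut one bond further out this reads butoxycarbonyl to methylcarbamoyl. Among the compounds with values here, no measured step exchanges these two groups, so nothing in hand speaks directly to this change. Within the data shown here, the only step that bears on it at all is the one bringing in the carbonyl-bearing substituent, and compound 4 keeps such a substituent; because a number 26 percentage points higher from compound 2 to compound 3 (beyond the scatter) was modest and beyond the scatter, compound 4 is expected to stay nearer compound 3 than compound 2, with a wide range. The expected step of a number 9 percentage points lower from compound 3 to compound 4 (within the scatter) is a small fall that may not exceed the scatter. Compound 4 is estimated at 52%, between 28% and 74%.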

Compound 4, a percentage reported as inhibition, at one concentration (the size of the read-out at that concentration, not a potency): 40%
Estimate against measurement, compound 4: 12 percentage points above; measured number inside the range.
By their numbers in this assay, from the lowest: compounds 2 and 4 (each within the scatter of the next); then compound 3; then compound 1.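

In this assay, methylamino in place of butoxy on a carbonyl carbon gives a number 21 percentage points lower from compound 3 to compound 4 (beyond the scatter), so a carbonyl at this place does not by itself preserve the number seen with butoxycarbonyl. Methylcarbamoyl in place of hydrogen on an aromatic carbon gives a number 5 percentage points higher from compound 2 to compound 4 (within the scatter), which lies within the scatter, so this substituent shows no clear gain over hydrogen. Nothing in hand accounts for the difference between the two groups.

The butoxy-to-methylamino change alters the chain and the atom attached to the carbonyl carbon together, and the compounds shown do not separate these two changes. Butylamino or methoxy on the same carbonyl carbon would pull them apart, while a carboxylic acid there remains an open comparison.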